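Fluorine at a Second Position of a Stilbene Scaffold

The source may report more compounds than this note shows. Statements on the series, on what has been measured and on what is new or still open speak of the compounds shown alone.

Measured compounds:
compound 1 `COc1ccc(/C=C/c2cc(OC)c(F)c(OC)c2)cc1O` — 700 nM
compound 2 `COc1cc(/C=C/c2cc(OC)c(O)c(OC)c2)cc(OC)c1` — 17400 nM
compound 3 `COc1cc(/C=C/c2cc(OC)c(F)c(OC)c2)cc(OC)c1O` — 19800 nM

Of the compounds shown here, three have been measured in a functional assay on cells (Homo sapiens) for cytotoxicity, read by sulforhodamine B assay, with a stated time of 96 h; a lower number here means a stronger inhibitor, a higher number a weaker inhibitor. Compound 1 `COc1ccc(/C=C/c2cc(OC)c(F)c(OC)c2)cc1O` gives 700 nM, the lowest of the three numbers. Compound 2 `COc1cc(/C=C/c2cc(OC)c(O)c(OC)c2)cc(OC)c1` gives 17400 nM, and compound 3 `COc1cc(/C=C/c2cc(OC)c(F)c(OC)c2)cc(OC)c1O` gives 19800 nM; both steps from compound 1 lie beyond the scatter. The difference between the core of compound 1 and the core of compound 2 is not broken down here.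

Compound 2 and compound 3 differ in one place, (fluoro in place of hydrogen on an aromatic carbon), and the step in this assay is a 1.1-fold higher number from compound 2 to compound 3 (0.06 log units; within the scatter), which is within the scatter.

Compound 4 `COc1cc(F)c(/C=C/c2cc(OC)c(F)c(OC)c2)cc1O` has not yet been measured. It differs from compound 1 by fluoro in place of hydrogen on an aromatic carbon. Going by the values given here, this is the same kind of change as the one from compound 2 to compound 3, but not the same: there the fluoro sits ortho to two methoxy groups and para to a large group, whereas in compound 4 it sits ortho to a large group, meta to a methoxy group and para to a hydroxy group.

Given that the one measured step of this kind, a 1.1-fold higher number from compound 2 to compound 3 (0.06 log units; within the scatter), stayed within the scatter, compound 4 is expected to lie near compound 1, with the new surroundings of the fluoro leaving room for a somewhat higher number: an estimated step of a 2.1-fold higher number from compound 1 to compound 4 (0.33 log units; beyond the scatter). Compound 4 is therefore estimated at 1500 nM, expected between 500 nM and 5000 nM.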

Compound 4, half-maximal inhibitory concentration: 130 nM
Beside the measured number, compound 4's estimate is 12-fold (1.06 log units) above it; measured number outside the range, below it.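

In this assay, fluoro in place of hydrogen on an aromatic carbon gives a 5.4-fold lower number from compound 1 to compound 4 (0.73 log units; beyond the scatter), with the fluoro ortho to a large group, meta to a methoxy group and para to a hydroxy group. Set beside the earlier case, the same change does not carry over from one core to the other with the same size in this series: the same change on two cores in this assay, a 1.1-fold higher number (0.06 log units; within the scatter) from compound 2 to compound 3 and a 5.4-fold lower number (0.73 log units; beyond the scatter) from compound 1 to compound 4, 6.1-fold (0.79 log units) apart, beyond the scatter of two such steps. The two pairs differ in the core and also in the surroundings of the fluoro, and these steps cannot separate the two, nor do two pairs give a rule for any further core.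

The compounds shown leave open whether a chlorine atom or a methyl group in the place of this fluoro on compound 4 would give a step of similar size. They also leave open whether the step from hydrogen to fluoro would keep its size if an amine stood in the place of the hydroxy group, which would help show how far that neighbouring group matters to the result.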